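The source may report more compounds than this note shows. Statements on the series, on what has been measured and on what is new or still open speak of the compounds shown alone.

Compound 1, `Cc1ccc(NC(=O)N(Cc2ccccn2)n2cnnc2)cc1`, is a urea that carries a 4-methylphenyl group on one of its amide-type nitrogens. In a functional assay on MDA-MB-231 cells (Homo sapiens) for cytotoxicity, read by MTT assay, with a stated time of 48 h (a lower number here means a stronger inhibitor, a higher number a weaker inhibitor), compound 1 gives 39500 nM. Among the two values shown here it holds the only plain number, so it stands alone on that score. Compound 2, `CCCCCCCCCNC(=O)N(Cc1cc(OC)ccc1OC)n1cnnc1`, belongs to the same set. In this assay compound 2 gives > 50000 nM, which is a limit of the measurement and not a number (the limit of > 50000 nM in this assay, at which 1 of the 2 values shown sits). Compound 3, `O=C(NC1CCCCC1)N(Cc1ccccn1)n1cnnc1`, has not yet been measured. It differs from compound 1 in one place: cyclohexyl in place of 4-methylphenyl on an amide-type nitrogen. Within the data shown here, no two measured compounds here differ in a single place, so there is no measured step to lean on. Given that compound 1 gives 39500 nM, the change is expected to move the result little, staying within the usual scatter or drifting toward a weaker inhibitor. Compound 3 is expected to show about 48000 nM, within a range from 20000 nM to 120000 nM. The expected step is a 1.2-fold higher number from compound 1 to compound 3 (0.08 log units; within the scatter).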

Compound 3, half-maximal inhibitory concentration: 44100 nM
The estimate for compound 3 lay 1.1-fold (0.04 log units) above the measured number; measured number inside the range.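

In this assay, among these compounds, the step of a 1.1-fold higher number from compound 1 to compound 3 (0.05 log units; within the scatter) is the first comparison in this set between two compounds that differ in one place, and it lies within the scatter, so the two compounds cannot be told apart. On this amide-type nitrogen, the 4-methylphenyl group and the cyclohexyl group give results that cannot be separated, which means that in this pair an aromatic ring at this place is not needed to reach this level of activity. Compound 2 remains a limit and not a number, so this single step is the only measured comparison the set offers: the limit of > 50000 nM in this assay, at which 1 of the 3 values shown sits.

Still open, on these data alone, is whether any group on this nitrogen can give a clearly stronger inhibitor, as both rings compared here consist of carbon only and have no hydrogen-bond donors or acceptors. A ring carrying an amine or a carboxylic acid on the core of compound 1 would probe that question, and one pair cannot tell whether the same holds elsewhere on the core.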